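From a hydroxyethyl pyrazole to a fluoromethoxyphenyl group

The source may hold more compounds than are shown below. What is called first, only, known or untested is meant among the compounds shown, and "the series" means these compounds.

Measured so far in a functional assay on EBC-1 cells (Homo sapiens) for antiproliferative activity, with a stated time of 72 h; on this read-out lower numbers stand for stronger inhibition and higher numbers for weaker inhibition:
compound 1 `Cn1cc(-c2cn3c(Cc4ccc5ncccc5c4)cnc3cc2C(F)(F)F)cn1` gives "not determined" (no result reported)
compound 2 `OCCn1cc(-c2cc(F)c3ncc(Cc4ccc5ncccc5c4)n3c2)cn1` gives 0.34 nM
compound 3 `Fc1cc(-c2cnn(C3CCNCC3)c2)cn2c(Cc3ccc4ncccc4c3)cnc12` gives 1.46 nM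

Of the two numbers in this assay, compound 2 holds the lower (0.34 nM). Compound 4 `COc1ccc(-c2cc(F)c3ncc(Cc4ccc5ncccc5c4)n3c2)cc1F` keeps the shared core of compound 2 and makes one change: 3-fluoro-4-methoxyphenyl in place of 1-(2-hydroxyethyl)-1H-pyrazol-4-yl on an aromatic carbon. Within the data shown here, only one measured step bears on this, a 4.3-fold higher number from compound 2 to compound 3 (0.63 log units; beyond the scatter). That step altered only a group on an aromatic nitrogen, whereas here the whole 1-(2-hydroxyethyl)-1H-pyrazol-4-yl leaves, so it is a rough guide at best. A modest rise is expected, meaning weaker inhibition: a 4.4-fold higher number from compound 2 to compound 4 (0.64 log units; beyond the scatter). For compound 4 the estimated value is 1.5 nM, with an expected range from 0.4 nM to 6 nM.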

Compound 4, half-maximal inhibitory concentration: 407 nM
Compound 4: the middle estimate sits 270-fold (2.43 log units) below what was measured; the measured number lies above the stated range.
By their numbers in this assay, from the lowest: compound 2; then compound 3; then compound 4.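

At this aromatic carbon of the shared core, the group matters greatly: in this assay, 3-fluoro-4-methoxyphenyl in place of 1-(2-hydroxyethyl)-1H-pyrazol-4-yl gives a 1200-fold higher number from compound 2 to compound 4 (3.08 log units; beyond the scatter). The earlier change on an aromatic nitrogen gave only a 4.3-fold higher number from compound 2 to compound 3 (0.63 log units; beyond the scatter), so a low number here does not survive every replacement of the whole group. No measurement shown here offers an explanation for this large rise. The ring and its substituents changed together, so their separate contributions cannot be told apart. From the compounds shown here alone, whether a phenyl ring carrying a 2-hydroxyethyl chain or an amine would restore a low number remains open.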